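Sulfonyl substituent and cytotoxicity in the anilide series

This account rests on a few compounds, and the source may have more. Where it says the series, first, only, none or still open, it means among the compounds named here.

Compound 1 `COc1cc(NC(=O)c2cc(C(F)(F)F)cc(C(F)(F)F)c2)ccc1NS(=O)(=O)C(F)(F)F`: a limit in an ADME assay on RAW264.7 cells (Mus musculus) for cytotoxicity, read by MTT assay, with a stated time of 48 h (on this read-out lower numbers stand for stronger inhibition and higher numbers for weaker inhibition), > 250000 nM.
Compound 2 `CS(=O)(=O)Nc1ccc(NC(=O)c2cc(C(F)(F)F)cc(C(F)(F)F)c2)cc1Cl`: 69600 nM.
Compound 3 `CCS(=O)(=O)Nc1ccc(NC(=O)c2cc(C(F)(F)F)cc(C(F)(F)F)c2)cc1Cl`: 64100 nM.

Compound 3 gives the lowest of the two numbers; its nearest neighbour is compound 2, and the step of a 1.1-fold lower number from compound 2 to compound 3 (0.04 log units; within the scatter) lies within the scatter. The remaining value, that of compound 1, is a limit only.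

Compound 4 `O=C(Nc1ccc(NS(=O)(=O)C(F)(F)F)c(Cl)c1)c1cc(C(F)(F)F)cc(C(F)(F)F)c1` differs from compound 3 by trifluoromethyl in place of ethyl on a sulfonyl sulfur. Going by the values given here, no measured step covers this exchange. Among the compounds with values here, the only measured step on the sulfonyl substituent, a 1.1-fold lower number from compound 2 to compound 3 (0.04 log units; within the scatter), is within the scatter. Compound 1, which also carries a trifluoromethyl on its sulfonyl sulfur, gave only the limit (the limit of > 250000 nM in this assay, at which 1 of the 3 values shown sits).

For compound 4 a somewhat higher number is expected, a 1.9-fold higher number from compound 3 to compound 4 (0.27 log units; within the scatter), with an estimate of 120000 nM and a range from 40000 nM to 300000 nM.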

Compound 4, half-maximal inhibitory concentration: 136000 nM
Estimate against measurement, compound 4: 1.1-fold (0.05 log units) below; measured number inside the range.
By their numbers in this assay, from the lowest: compounds 3, 2 and 4 (each within the scatter of the next, the first and the last beyond it). At a limit, above all of these: compound 1.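

Trifluoromethyl in place of ethyl on a sulfonyl sulfur gives a 2.1-fold higher number from compound 3 to compound 4 (0.33 log units; beyond the scatter) in this assay, the first step at this position beyond the scatter. Against methyl, the same exchange gives a 2.0-fold higher number from compound 2 to compound 4 (0.29 log units; within the scatter) and stays within it. Chloro in place of methoxy on an aromatic carbon can be read only as a floor, an at least 1.8-fold lower number from compound 1 to compound 4 (0.26 log units; that floor lies within the scatter) and no more, since one side of the step is a limit: the limit of > 250000 nM in this assay, at which 1 of the 4 values shown sits.

Going by these compounds, whether a longer chain or an amine on the sulfonyl sulfur would shift the number remains open. Also open, on these data alone, is how a hydrogen or a fluoro in place of the chloro would read.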